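Methyl on the Phenol Oxygen: From Compound 2 to Compound 4

The source may hold more compounds than are shown below. What is called first, only, known or untested is meant among the compounds shown, and "the series" means these compounds.

Compound 1 `CC1(/C=C/c2ccccc2O)C=CC(=O)O1` and compound 2 `CC1(/C=C/c2ccc(O)cc2)C=CC(=O)O1` are built from the same atoms joined differently; how their two cores differ is not broken down here. In a functional assay on K562 cells (Homo sapiens) for inhibition, read by sulforhodamine B assay, with a stated time of 48 h (on this read-out lower numbers stand for stronger inhibition of growth and higher numbers for weaker inhibition of growth), compound 1 gives only a limit, > 1000000 nM. Compound 2 also gives only a limit in this assay, > 1000000 nM. Compound 3 `COc1ccccc1/C=C/C1(C)C=CC(=O)O1` differs from compound 1 by methyl in place of hydrogen on an oxygen on an aromatic ring. In this assay compound 3 gives 860000 nM, and the step of an at least 1.1-fold lower number from compound 1 to compound 3 (0.06 log units; that floor lies within the scatter). That step is a floor rather than a measured size because of the limit of > 1000000 nM in this assay, at which 2 of the 3 values shown sit. Compound 4 `COc1ccc(/C=C/C2(C)C=CC(=O)O2)cc1` differs from compound 2 by methyl in place of hydrogen on an oxygen on an aromatic ring; the place of the change is the same, so this is the same change carried onto the core of compound 2. The step from compound 2 to compound 4 is expected to be small, an at least 1.1-fold lower number from compound 2 to compound 4 (0.04 log units; that floor lies within the scatter), because the earlier step of an at least 1.1-fold lower number from compound 1 to compound 3 (0.06 log units; that floor lies within the scatter) did not leave the scatter. Compound 4 is therefore estimated at 900000 nM in this assay, between 400000 nM and 2000000 nM, with a real chance that only a limit is reported again.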

Compound 4, concentration for total growth inhibition: > 1000000 nM
Compound 4 gave a limit, no number (the forecaster's own chance of this, stated with the estimate: 50%); middle value at least 1.1-fold (0.04 log units) from the limit.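

No step can be read from compound 2 to compound 4, since both give only a limit and no number: the limit of > 1000000 nM in this assay, at which 3 of the 4 values shown sit.

The compounds shown leave open whether hydroxy to methoxy on the core of compound 2 changes growth inhibition at all in this assay, and how the two compounds would compare if both gave measured numbers.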